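One fluoro fewer on compound 2

The source may hold more compounds than are shown below. What is called first, only, known or untested is meant among the compounds shown, and "the series" means these compounds.

Compound 1 `O=C(Nc1ccc([N+](=O)[O-])cc1Cl)c1cc([N+](=O)[O-])ccc1O`: > 50 ug/mL, a limit of the assay
Compound 2 `O=C(Nc1ccc(F)cc1F)c1cc(Cl)ccc1O`: 1 ug/mL

Within the data shown here, in a physicochemical assay for solubility (a lower number here means a less soluble compound, a higher number a more soluble compound), compound 2 gives 1 ug/mL, the only true number so far. Compound 1 reads > 50 ug/mL, which is a limit of the assay and not a number. Compound 3 `O=C(Nc1ccc(F)cc1)c1cc(Cl)ccc1O` differs from compound 2 in a single place: hydrogen in place of fluoro on an aromatic carbon. Among the measured compounds shown here, no measured step covers this change, so no shift beyond the scatter is expected in this assay. The expected value for compound 3 is 1.5 ug/mL, with an estimated range of 0.5 ug/mL to 5 ug/mL. This estimate amounts to an expected 1.5-fold higher number from compound 2 to compound 3 (0.18 log units; within the scatter).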

Compound 3, solubility: 1.6 ug/mL
The estimate for compound 3 lay 1.1-fold (0.03 log units) below the measured number; measured number inside the range.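

In this assay, hydrogen in place of fluoro on an aromatic carbon, ortho to a large group, gives a 1.6-fold higher number from compound 2 to compound 3 (0.20 log units; within the scatter). This is a measured step at this position, and it shows that this fluoro can leave without a shift beyond the scatter. Nothing shown here bears on why this step is so small.

The compounds shown leave open whether an amine, a methoxy group or a carboxylic acid at this place would move the number beyond the scatter. Also open, from the compounds shown here alone, is what replacing the fluoro group that compound 3 keeps would do.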